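Adding a Methyl to an Aromatic Ring in Compound 4

A few compounds are considered here, and "the series" means these few. Any claim that something is new, unique, unknown or untested is made for them only; others in the source may bear on it.

In a functional assay on the whole organism (strain Wistar) for inhibition, with Rattus norvegicus as the target, with stated times of 30 min and 2 h, at a dose of 20 mg/kg by the oral route (a lower number here means less inhibition, a higher number more inhibition at the dose given (going by the name of the read-out)), compound 1 `Cc1ccc(C(=O)CCc2nnc(Cc3ccccc3)o2)c(C)c1` gives 25.3%.
In this assay compound 2 `Cc1ccc(C(=O)CCc2nnc(COc3ccccc3)o2)c(C)c1` gives 27.6%.
In this assay compound 3 `O=C(CCc1nnc(COc2ccc3ccccc3c2)o1)c1ccccc1` gives 29.8%.

Compound 3 holds the highest of the three numbers, yet its gaps to compound 2 and to compound 1 both lie within the scatter, so no order among the three can be read. Within the data shown here, the only single-place step measured, a number 2.3 percentage points higher from compound 1 to compound 2 (within the scatter), also stays within the scatter. Compound 4 `Cc1ccc(C(=O)CCc2nnc(COc3ccc4ccccc4c3)o2)cc1` differs from compound 3 by methyl in place of hydrogen on an aromatic carbon. Among the measured compounds shown here, no measured step involves a methyl entering on an aromatic carbon, and nothing among the three values points to a shift in either direction. For compound 4 in this assay the expected step is a number 0.2 percentage points higher from compound 3 to compound 4 (within the scatter), none beyond the scatter. Compound 4 is therefore estimated at 30%, between 18% and 42%.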

Compound 4, a percentage reported as inhibition, in the whole organism at one dose (the size of the read-out at that dose, not a potency): 24.7%
Estimate against measurement, compound 4: 5.3 percentage points above, and the stated range covers the measured number.
By their numbers in this assay, from the lowest: compounds 4, 1, 2 and 3 (each within the scatter of the next).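

This is the only measured case of a methyl entering on an aromatic carbon, here turning benzoyl into (4-methylphenyl)carbonyl. In this assay this swap reads a number 5.1 percentage points lower from compound 3 to compound 4 (within the scatter), so at this place, para to a large group, a methyl does not separate the two compounds beyond the scatter. Nothing measured here bears on the reason for this result.

As far as these compounds go, whether a methoxy group, an amine or a carboxylic acid at the same place would move the number beyond the scatter stays open. So does the outcome with a longer chain in place of the methyl.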